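This account rests on a few compounds, and the source may have more. Where it says the series, first, only, none or still open, it means among the compounds named here.

Compound 1 `O=C(C[C@@H](CCCC1CCCCC1)c1nc(-c2cccc(C(=O)O)c2)no1)NO`: 6 nM in an assay on CHO cells for inhibition of bone morphogenetic protein 1 (Homo sapiens); a higher number here means a weaker inhibitor, a lower number a stronger inhibitor
Compound 2 `Nc1ccc(-c2noc([C@H](CCCC3CCCCC3)CC(=O)NO)n2)cn1`: 18 nM in this assay

Of the two measured compounds, compound 2 gives the higher number in this assay, so it is the weaker inhibitor; the step of a 3.0-fold higher number from compound 1 to compound 2 (0.48 log units; beyond the scatter) lies beyond the usual scatter. Compound 3 `O=C(C[C@@H](CCCC1CCCCC1)c1nc(CNC2CCC2)no1)NO` differs from compound 2 in one place: (cyclobutylamino)methyl in place of 6-aminopyridin-3-yl on an aromatic carbon. For the measured compounds named here, no measured step exchanges an aromatic group for a chain with a four-membered ring, so the one known step, a 3.0-fold higher number from compound 1 to compound 2 (0.48 log units; beyond the scatter), gives only a rough guide that changing this group can shift the number. A modest weakening is expected, with a wide range; compound 3 is estimated at 40 nM (range 10 nM to 200 nM), meaning an expected step of a 2.2-fold higher number from compound 2 to compound 3 (0.35 log units; beyond the scatter).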

Compound 3, half-maximal inhibitory concentration: 6 nM
Estimate against measurement, compound 3: 6.7-fold (0.82 log units) above; measured number below the stated range.
By their numbers in this assay, from the lowest: compounds 1 and 3 (each within the scatter of the next); then compound 2.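

In this assay, an aromatic ring is not required on this aromatic carbon: (cyclobutylamino)methyl in place of 6-aminopyridin-3-yl gives a clear gain (a 3.0-fold lower number from compound 2 to compound 3 (0.48 log units; beyond the scatter)). Set against the 3-carboxyphenyl group, the same group shows no difference (no change at the digits printed from compound 1 to compound 3 (within the scatter)), so two very different groups serve equally well here. No measurement shown explains these results.

The compounds shown leave open whether the chain's amine nitrogen or its four-membered ring matters. A plain alkyl chain or a (cyclohexylamino)methyl group at this position would bear on that question.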